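This account rests on a few compounds, and the source may have more. Where it says the series, first, only, none or still open, it means among the compounds named here.

In a functional assay on MCF-10A cells (Homo sapiens) for antiproliferative activity, with a stated time of 48 h (a higher number here means that more compound is needed for the effect, a lower number that less compound is needed), compound 1 `Cc1cc(NCc2ccc(F)cc2)c2ccccc2n1`, which has hydrogen where the others carry a chain, gives 15400 nM for the shared core. Compound 2 `CCCOc1ccc2nc(C)cc(NCc3ccc(F)cc3)c2c1` carries a propoxy group and gives 9800 nM on the same measure. Compound 3 `CCCCCCOc1ccc2nc(C)cc(NCc3ccc(F)cc3)c2c1` carries a hexyloxy group and gives 8800 nM which lies within the scatter of both other compounds, so the three cannot be told apart here.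

Compound 4 `CCCCCCCCOc1ccc2nc(C)cc(NCc3ccc(F)cc3)c2c1` extends the hexyloxy chain, and the change is ethyl in place of hydrogen on a saturated chain carbon, six bonds along the chain from an oxygen on an aromatic ring with nothing else altered. The closest measured change is a 1.1-fold lower number from compound 2 to compound 3 (0.05 log units; within the scatter) for adding propyl to the same chain. Putting a chain on the core at all gave a 1.6-fold lower number from compound 1 to compound 2 (0.20 log units; within the scatter) for propoxy and a 1.8-fold lower number from compound 1 to compound 3 (0.24 log units; within the scatter) for hexyloxy. All three steps are small, so no step beyond the scatter is expected in this assay for the added ethyl. The expected step is a 1.0-fold lower number from compound 3 to compound 4 (0.02 log units; within the scatter) in this estimate. No chain longer than hexyloxy has been measured yet, so the range stays wide. Compound 4 is estimated at 8500 nM with an expected range of 4500 nM to 16000 nM in this series.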

Compound 4, half-maximal effective concentration: 1800 nM
Compound 4: the middle estimate sits 4.7-fold (0.67 log units) above what was measured, and the stated range ends above it.
By their numbers in this assay, from the lowest: compound 4; then compounds 3, 2 and 1 (each within the scatter of the next).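

Within this assay the move from hexyloxy to octyloxy gives a 4.9-fold lower number from compound 3 to compound 4 (0.69 log units; beyond the scatter) and so, unlike any earlier step, clears the scatter, as do a 5.4-fold lower number from compound 2 to compound 4 (0.74 log units; beyond the scatter) and an 8.6-fold lower number from compound 1 to compound 4 (0.93 log units; beyond the scatter) when octyloxy is set against propoxy and against plain hydrogen. The response to chain length at this position is therefore not gradual across these compounds: hydrogen, propoxy and hexyloxy cannot be told apart, while the ethyl added at the far end of the hexyloxy chain separates compound 4 from all three. Nothing available here explains why the number falls at this chain length.

As far as these compounds go, whether a longer chain than octyloxy lowers the number further or raises it again remains open. Also open, from the compounds shown here alone, is whether a branched chain, or an octyl chain ending in an amine, would behave in the same way.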